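The source may hold more compounds than are shown below. What is called first, only, known or untested is meant among the compounds shown, and "the series" means these compounds.

Measured compounds:
compound 1 `CCCS(=O)(=O)Nc1ccc(F)c(C(=O)c2n[nH]c3ncc(-c4ccc(OC)cc4Cl)cc23)c1F`: 5.3%
compound 2 `CCCS(=O)(=O)Nc1ccc(F)c(C(=O)c2n[nH]c3ncc(-c4cccc([N+](=O)[O-])c4)cc23)c1F`: 15%

In an assay for binding affinity to dual specificity mitogen-activated protein kinase kinase 4 (Homo sapiens), read by KINOMEscan, tested at 100 nM (on this read-out lower numbers stand for a stronger effect and higher numbers for a weaker effect at the one concentration tested), compound 2 carries the higher of the two numbers, with compound 1 nearest: a number 9.7 percentage points higher from compound 1 to compound 2 (within the scatter). Compound 3 `CCCS(=O)(=O)Nc1ccc(F)c(C(=O)c2n[nH]c3ncc(-c4ccc(NS(C)(=O)=O)cc4)cc23)c1F` is the next compound, differing from compound 2 in one place: 4-(methanesulfonamido)phenyl in place of 3-nitrophenyl on an aromatic carbon. Among the measured compounds shown here, the one measured step that bears on this change, a number 9.7 percentage points higher from compound 1 to compound 2 (within the scatter), also swapped the aryl group on the same carbon and gave a step within the scatter, so for compound 3 an expected step of a number 5 percentage points lower from compound 2 to compound 3 (within the scatter) in this assay, none beyond the scatter, seems reasonable. Compound 3 is therefore estimated at 10%, between 2% and 35%.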

Compound 3, a percentage reported as activity, at one concentration (the size of the read-out at that concentration, not a potency): 0.85%
Estimate against measurement, compound 3: 9.2 percentage points above; measured number outside the range, below it.
By their numbers in this assay, from the lowest: compounds 3, 1 and 2 (each within the scatter of the next, the first and the last beyond it).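

In this assay, among the compounds shown here, this aryl carbon now shows a first change beyond the scatter, with 4-(methanesulfonamido)phenyl replacing 3-nitrophenyl giving a number 14.2 percentage points lower from compound 2 to compound 3 (beyond the scatter). Replacing 2-chloro-4-methoxyphenyl with the same group gives a number 4.5 percentage points lower from compound 1 to compound 3 (within the scatter), so compound 1 and compound 3 cannot be told apart here, and only the 3-nitrophenyl compound stands apart from compound 3. Nothing available explains the difference. The compounds shown leave open whether a 4-aminophenyl or 4-carboxyphenyl group on this carbon would match the methanesulfonamido group.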